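Removing the aryl group from the side chain

The source may hold more compounds than are shown below. What is called first, only, known or untested is meant among the compounds shown, and "the series" means these compounds.

Values in a functional assay on PC-3 cells (Homo sapiens) for cytotoxicity, read by MTT assay, with a stated time of 72 h; a higher number here means a weaker inhibitor, a lower number a stronger inhibitor:
- compound 1 `CCCOCNc1n[n+]([O-])c2cc(OC)ccc2[n+]1[O-]`: 6570 nM
- compound 2 `[O-][n+]1nc(NCOCc2ccc(C(F)(F)F)cc2)[n+]([O-])c2ccccc21`: 7650 nM
- compound 3 `[O-][n+]1nc(NCOCc2ccc(Cl)cc2)[n+]([O-])c2ccccc21`: 5760 nM

Compound 3 at 5760 nM stands level with compound 1 and compound 2, all three values lying within the scatter of each other. The next compound to consider is compound 4 `COCNc1n[n+]([O-])c2ccccc2[n+]1[O-]`, which has hydrogen in place of 4-chlorophenyl on a saturated chain carbon bound to an oxygen on a saturated carbon.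

Among the compounds with values here, the only measured single-place step is a 1.3-fold lower number from compound 2 to compound 3 (0.12 log units; within the scatter). It lies within the scatter, but it only exchanges one ring substituent for another and does not remove the ring. Compound 1 gives closer, though indirect, evidence: it also has no aromatic ring on its chain and gives 6570 nM, but its core differs as well. Within the data shown here, no measured step therefore points to a large change, and no shift beyond the scatter is expected in this assay. The expected step is small and slightly upward, a 1.4-fold higher number from compound 3 to compound 4 (0.14 log units; within the scatter). For compound 4 the estimated value is 8000 nM, with an expected range of 3500 nM to 20000 nM.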

Compound 4, half-maximal inhibitory concentration: 7510 nM
Compound 4: middle estimate off by 1.1-fold (0.03 log units), on the high side, within the range that was stated.
By their numbers in this assay, from the lowest: compounds 3, 1, 4 and 2 (each within the scatter of the next).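

In this assay, putting hydrogen in place of 4-chlorophenyl on a saturated chain carbon bound to an oxygen on a saturated carbon gives a 1.3-fold higher number from compound 3 to compound 4 (0.12 log units; within the scatter) and so removes the whole aromatic ring, which the earlier exchange of one ring substituent for another left in place. On the shared core, the ring at this position is therefore not needed for a value at this level in this cell assay. No measurement shown here accounts for the size of this step.

Still open, on these data alone, is whether any group at this position moves the value beyond the scatter, for example a longer alkyl chain, a terminal amine or a carboxylic acid. The compounds shown also leave open whether the same removal gives a similar step on the methoxy-bearing core of compound 1.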